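The source may report more compounds than this note shows. Statements on the series, on what has been measured and on what is new or still open speak of the compounds shown alone.

In a functional assay on HT-29 cells (Homo sapiens) for cytotoxicity, read by MTT assay, with a stated time of 72 h (on this read-out lower numbers stand for stronger inhibition and higher numbers for weaker inhibition), compound 3 `COc1cc2c(Oc3ccc(NC(=O)c4nccc(-c5ccc(F)cc5)n4)cc3F)ccnc2cc1OCCCN1CCN(C)CC1` gives 42 nM, the lowest of the three numbers shown. Compound 2 `COc1cc2c(Oc3ccc(NC(=O)c4nccc(-c5ccc(C)cc5)n4)cc3F)ccnc2cc1OCCCN1CCN(C)CC1` gives 210 nM, and compound 1 `COc1cc2c(Oc3ccc(NC(=O)c4nccc(-c5ccc(F)cc5F)n4)cc3F)ccnc2cc1OCCCN1CCCCC1` gives 400 nM. Compound 4 `COc1cc2c(Oc3ccc(NC(=O)c4nccc(-c5ccc(F)cc5F)n4)cc3F)ccnc2cc1OCCCN1CCN(C)CC1` differs from compound 3 by fluoro in place of hydrogen on an aromatic carbon. For the measured compounds named here, no measured step bears on this change directly; the only single-point step, a 5.0-fold lower number from compound 2 to compound 3 (0.70 log units; beyond the scatter), concerns a different swap. Compound 1 carries the same 2,4-difluorophenyl but another amine tail, so its value and that of compound 3 differ in two places at once and do not isolate the effect. The step is therefore expected to be small, a 2.4-fold higher number from compound 3 to compound 4 (0.38 log units; beyond the scatter), if anything toward a higher number. Compound 4 is estimated at 100 nM, within 30 nM to 350 nM.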

Compound 4, half-maximal inhibitory concentration: 480 nM
Compound 4: middle estimate off by 4.8-fold (0.68 log units), on the low side; measured number outside the range, above it.
By their numbers in this assay, from the lowest: compound 3; then compounds 2, 1 and 4 (each within the scatter of the next, the first and the last beyond it).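

In this assay, adding fluoro on an aromatic carbon ortho to a large group, which turns 4-fluorophenyl into 2,4-difluorophenyl, proves costly (an 11-fold higher number from compound 3 to compound 4 (1.06 log units; beyond the scatter)). That loss also carries this compound past the 4-methylphenyl analogue (a 2.3-fold higher number from compound 2 to compound 4 (0.36 log units; beyond the scatter)), while with 2,4-difluorophenyl in place, the change of amine tail stays within the scatter (a 1.2-fold higher number from compound 1 to compound 4 (0.08 log units; within the scatter)). Nothing available here accounts for the loss. On these data alone, whether chloro or methoxy at this position would be tolerated any better remains open. So does the behaviour of 2-fluorophenyl.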